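Methoxy to hydroxy: working notes on a small series

A few compounds are considered here, and "the series" means these few. Any claim that something is new, unique, unknown or untested is made for them only; others in the source may bear on it.

- compound 1 (`COc1cc2c(cc1C)NC(=O)/C2=C/c1c(OC)nc2sc(C)cn12`) gives 7220 nM here
- compound 2 (`COc1ccc2c(c1)/C(=C\c1c(OC)nc3sc(C)cn13)C(=O)N2`) gives 1320 nM here

These values come from a functional assay on cells (Ovarian carcinoma cell, Homo sapiens) for cytotoxicity, read by sulforhodamine B assay, with a stated time of 48 h (a lower number here means a stronger inhibitor of growth, a higher number a weaker inhibitor of growth), and compound 2 holds the lower of the two numbers. Compound 3 (`COc1nc2sc(C)cn2c1/C=C1/C(=O)Nc2ccc(O)cc21`) differs from compound 2 by hydrogen in place of methyl on an oxygen on an aromatic ring (hydrogen in place of methyl on an oxygen on an aromatic ring, methoxy to hydroxy). Among the measured compounds shown here, the only measured step (a 5.5-fold lower number from compound 1 to compound 2 (0.74 log units; beyond the scatter)) is modest and lies at a different place, on an aromatic carbon. It offers no firm direction for this change. The expected step, with little support from the data, is a 1.1-fold higher number from compound 2 to compound 3 (0.06 log units; within the scatter) and may not exceed the scatter. Compound 3 is estimated at 1500 nM in this assay (expected range 450 nM to 5500 nM).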

Compound 3, concentration for 50% growth inhibition: 12900 nM
Beside the measured number, compound 3's estimate is 8.6-fold (0.93 log units) below it; the measured number lies above the stated range.
By their numbers in this assay, from the lowest: compound 2; then compounds 1 and 3 (each within the scatter of the next).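

In this assay, replacing methoxy with hydroxy gives a 9.8-fold higher number from compound 2 to compound 3 (0.99 log units; beyond the scatter) and so shows that this position is sensitive to the change: the methyl on the oxygen cannot be removed without weakening growth inhibition. The earlier step lay on an aromatic carbon and showed nothing about this oxygen. Nothing measured here bears on the reason for this step.

Going by these compounds, whether ethoxy or an amine in this place would match compound 2 at 1320 nM or improve on it stays open.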